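Dichlorobenzyl Swap Tested on a Weaker Amide Partner

The source may report more compounds than this note shows. Statements on the series, on what has been measured and on what is new or still open speak of the compounds shown alone.

Of the compounds shown here, three built on one shared core have been measured in a functional assay on HL-60 cells (Homo sapiens) for antiproliferative activity, with a stated time of 24 h; a higher number here means a weaker inhibitor, a lower number a stronger inhibitor. Compound 1, `NC(=O)c1c(NC(=O)c2ccccc2Cl)sc2c1CCN(Cc1ccc(Cl)cc1)C2`, gives 22500 nM in this assay. Compound 2, `NC(=O)c1c(NC(=O)c2ccccc2Cl)sc2c1CCN(Cc1c(Cl)cccc1Cl)C2`, differs from compound 1 by 2,6-dichlorophenyl in place of 4-chlorophenyl on a saturated chain carbon bound to an amine nitrogen in a ring, and compound 2 gives 4850 nM in this assay, which makes a 4.6-fold lower number from compound 1 to compound 2 (0.67 log units; beyond the scatter). Compound 3, `NC(=O)c1c(NC(=O)c2ccc(C(F)(F)F)cc2)sc2c1CCN(Cc1ccc(Cl)cc1)C2`, differs from compound 1 by 4-(trifluoromethyl)phenyl in place of 2-chlorophenyl on a carbonyl carbon. In this assay compound 3 reaches only a limit of the measurement, > 50000 nM. Set against compound 1, this reads as an at least 2.2-fold higher number from compound 1 to compound 3 (0.34 log units; beyond the scatter). Going by these compounds, the value of compound 3 rests on (the limit of > 50000 nM in this assay, at which 1 of the 3 values shown sits), so how far beyond that point it truly lies is unknown.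

Compound 4, `NC(=O)c1c(NC(=O)c2ccc(C(F)(F)F)cc2)sc2c1CCN(Cc1c(Cl)cccc1Cl)C2`, has not yet been measured in this assay. It differs from compound 3 by 2,6-dichlorophenyl in place of 4-chlorophenyl on a saturated chain carbon bound to an amine nitrogen in a ring, the same change that separates compound 2 from compound 1, and in the same place. Whether that change acts the same way on the core of compound 3, which carries 4-(trifluoromethyl)phenyl on the carbonyl carbon, is the open question. For the measured compounds named here, the only guide is the earlier pair, where the change gave a 4.6-fold lower number from compound 1 to compound 2 (0.67 log units; beyond the scatter), and the starting point being a limit rather than a number adds uncertainty. For compound 4 the expected step is an at least 2.5-fold lower number from compound 3 to compound 4 (0.39 log units; beyond the scatter). Compound 4 is estimated at 20000 nM, in a range from 6000 nM to 50000 nM.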

Compound 4, half-maximal inhibitory concentration: 10600 nM
The estimate for compound 4 lay 1.9-fold (0.28 log units) above the measured number, and the stated range covers the measured number.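

In this assay, 2,6-dichlorophenyl in place of 4-chlorophenyl again gives a stronger inhibitor on the core carrying 4-(trifluoromethyl)phenyl, with an at least 4.7-fold lower number from compound 3 to compound 4 (0.67 log units; beyond the scatter), while the carbonyl change on the 2,6-dichlorophenyl compounds gives a 2.2-fold higher number from compound 2 to compound 4 (0.34 log units; beyond the scatter). Compound 3 stands at a limit of the assay, > 50000 nM, so it supplies no exact starting number. The direction of the change therefore carries from one core to the other in these two pairs, but equal size on both cores is not shown: the same change on two cores in this assay, a 4.6-fold lower number (0.67 log units; beyond the scatter) from compound 1 to compound 2 and an at least 4.7-fold lower number (0.67 log units; beyond the scatter) from compound 3 to compound 4; the limit leaves it open whether they differ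

For the compounds shown here, these four compounds cover only two groups at each of the two places, so they leave open whether the same gain would appear with a single chlorine as 2-chlorophenyl, with a methoxy group or an amine on that ring, or with a carboxylic acid in place of the primary amide. They also leave open why the 2,6-dichlorophenyl compounds give the lower numbers, and whether the order would hold in any cell line other than the one tested in this assay.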